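Dropping the chloro from a weak sigma-1 binder

The source may hold more compounds than are shown below. What is called first, only, known or untested is meant among the compounds shown, and "the series" means these compounds.

Three compounds share a core and were measured in an assay on membranes from liver for displacement of a labelled ligand from Sigma non-opioid intracellular receptor 1 (Rattus norvegicus), read by scintillation counting; a higher number here means a weaker inhibitor, a lower number a stronger inhibitor. Compound 1 `CN(CCCn1c(=O)oc2ccccc21)Cc1ccc(Cl)cc1` gives 1150 nM, the highest number of the three. Compound 2 `CN(CCCCn1c(=O)oc2ccccc21)Cc1ccccc1`, which carries a plain benzyl group on a longer chain, gives 2.6 nM in this assay, and compound 3 `Cc1ccc(CN2CCC(Cn3c(=O)oc4ccccc43)CC2)cc1`, with a methyl-bearing benzyl group on a piperidine, gives 3.07 nM. Both of these stand far below compound 1, well beyond the usual scatter, so compound 1 is clearly the weakest inhibitor among the measured compounds.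

Compound 4 `CN(CCCn1c(=O)oc2ccccc21)Cc1ccccc1` has not yet been measured. It differs from compound 1 in one place: hydrogen in place of chloro on an aromatic carbon, so that the same difference, cut one bond further out, reads 4-chlorophenyl to phenyl. Among the measured compounds shown here, no pair of measured compounds isolates this change, since compound 2 differs from compound 1 also in chain length, so the size of the step in this assay is open.

Compound 4 is nevertheless expected to give a lower number than compound 1, because compound 2 gives 2.6 nM with the same plain benzyl group. The expected step from compound 1 to compound 4 is a 5.8-fold lower number from compound 1 to compound 4 (0.76 log units; beyond the scatter). Compound 4 is estimated at 200 nM, within a wide range from 15 nM to 2500 nM.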

Compound 4, inhibition constant: 223 nM
Estimate against measurement, compound 4: 1.1-fold (0.05 log units) below, within the range that was stated.
By their numbers in this assay, from the lowest: compounds 2 and 3 (each within the scatter of the next); then compound 4; then compound 1.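

In this assay, the change from 4-chlorophenyl to phenyl is now seen on its own, and hydrogen in place of chloro on an aromatic carbon, para to a large group, gives a 5.2-fold lower number from compound 1 to compound 4 (0.71 log units; beyond the scatter), a modest step that lies beyond the scatter. Losing this one chlorine does not close the distance to the strongest binders: compound 4, with its plain benzyl group, gives 223 nM, whereas compound 2, with the same plain benzyl group on a longer chain, gives 2.6 nM, so the chloro alone does not explain why compound 1 stood so far above compound 2. Nothing available here gives a reason for the size of this step.

The compounds shown leave open whether the same step would appear on the longer chain of compound 2 or on the piperidine of compound 3, where the chloro has no measured counterpart. They also leave open how a fluoro, a methoxy or a hydroxyl group on the same aromatic carbon would compare with chloro and hydrogen.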